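The source may hold more compounds than are shown below. What is called first, only, known or untested is meant among the compounds shown, and "the series" means these compounds.

Compounds measured in a functional assay on DU-145 cells (Homo sapiens) for inhibition, read by trypan blue exclusion, with a stated time of 96 h; a higher number here means a weaker inhibitor of growth, a lower number a stronger inhibitor of growth:
compound 1 `CN(C)c1ccc(/C=C(/SCc2ccc(Cl)cc2Cl)C(=O)c2ccc(Cl)cc2)cc1` gives 50000 nM
compound 2 `Cc1ccsc1/C=C(/SCc1ccc(Cl)cc1Cl)C(=O)c1ccc(Cl)cc1` gives 10000 nM
compound 3 `O=C(/C(=C\c1c(O)cc(O)cc1O)SCc1ccc(Cl)cc1Cl)c1ccc(Cl)cc1` gives 25000 nM

Compound 1 carries the highest of the three numbers. Its nearest neighbour is compound 3, which gives a 2.0-fold lower number from compound 1 to compound 3 (0.30 log units; within the scatter), so these two values lie within the scatter of one another and no order between them can be read. Compound 2 gives a 5.0-fold lower number from compound 1 to compound 2 (0.70 log units; beyond the scatter), a modest step beyond the scatter, while the step from compound 2 to compound 3, a 2.5-fold higher number from compound 2 to compound 3 (0.40 log units; beyond the scatter), is also modest.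

Compound 4 `CN(C)c1ccc(/C=C(/SCc2ccccc2Cl)C(=O)c2ccc(Cl)cc2)cc1` differs from compound 1 in one place: hydrogen in place of chloro on an aromatic carbon. Among the compounds with values here, all three measured steps concern the aromatic group on the double-bonded chain carbon; none of them touches the (2,4-dichlorobenzyl)sulfanyl part of the shared core, so no measured step bears on this change. With nothing in the data pointing in either direction, the expectation for compound 4 in this assay is a step of no change at the digits printed from compound 1 to compound 4 (within the scatter), that is, none beyond the scatter. Compound 4 is therefore estimated at 50000 nM, within a range of 20000 nM to 125000 nM.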

Compound 4, concentration for 50% growth inhibition: > 100000 nM
Compound 4 ended at the assay's limit; the forecaster's own chance of this, stated with the estimate: 20%; at least 2.0-fold (0.30 log units) between middle value and limit.
By their numbers in this assay, from the lowest: compound 2; then compounds 3 and 1 (each within the scatter of the next). At a limit, above all of these: compound 4.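

In this assay compound 4 gives > 100000 nM, which is a limit of the assay and not a number: the limit of > 100000 nM in this assay, at which 1 of the 4 values shown sits. Within the data shown here, the change from 2,4-dichlorobenzyl to 2-chlorobenzyl is the first in this set to fall on the (2,4-dichlorobenzyl)sulfanyl part of the shared core rather than on the aromatic group on the double-bonded chain carbon, and it reads as an at least 2.0-fold higher number from compound 1 to compound 4 (0.30 log units; that floor lies within the scatter). That floor lies within the scatter, so it does not by itself establish a weaker inhibitor, but it does show that hydrogen in place of the chloro group, para to a large group, brought no lower number than compound 1 had.

On these data alone, how far the true number of compound 4 lies from that of compound 1 remains open, as does whether this position would respond differently to a fluoro, methyl or methoxy group in place of the chloro group. Also open, as far as these compounds go, is whether the same change would read the same way with the 3-methylthiophen-2-yl group of compound 2 or the 2,4,6-trihydroxyphenyl group of compound 3 on the double-bonded chain carbon.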